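Chain extension on the nitro analogue of the enone series

The source may hold more compounds than are shown below. What is called first, only, known or untested is meant among the compounds shown, and "the series" means these compounds.

Measured so far in a functional assay on SK-N-SH cells (Homo sapiens) for inhibition, read by MTT assay; on this read-out lower numbers stand for stronger inhibition and higher numbers for weaker inhibition:
compound 1 `CCCCCCCCn1cc(/C=C/C(=O)c2ccc(NC(=O)CN3CCN(c4ccccc4)CC3)cc2)nn1` gives 41400 nM
compound 2 `CCCCCCCCCCn1cc(/C=C/C(=O)c2ccc(NC(=O)CN3CCN(c4ccccc4)CC3)cc2)nn1` gives 39500 nM
compound 3 `CCCCCCCCn1cc(/C=C/C(=O)c2ccc(NC(=O)CN3CCN(c4ccc([N+](=O)[O-])cc4)CC3)cc2)nn1` gives 51400 nM

All three compounds share one core and differ only at the chain end and on the phenyl attached to the piperazine. Compound 3 carries the highest of the three numbers, yet every gap to it is small: the step of a 1.2-fold higher number from compound 1 to compound 3 (0.09 log units; within the scatter) lies within the scatter, and compound 2 sits equally close.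

Compound 4 `CCCCCCCCCCn1cc(/C=C/C(=O)c2ccc(NC(=O)CN3CCN(c4ccc([N+](=O)[O-])cc4)CC3)cc2)nn1` differs from compound 3 by ethyl in place of hydrogen on a saturated chain carbon, eight bonds along the chain from an aromatic nitrogen. Among the compounds with values here, the one measured step of the same kind is a 1.0-fold lower number from compound 1 to compound 2 (0.02 log units; within the scatter), which extends the chain on the parent lacking the nitro group. No measurement exists for the longer chain combined with the nitro group. Since a 1.0-fold lower number from compound 1 to compound 2 (0.02 log units; within the scatter) stayed within the scatter, no step beyond the scatter is expected for compound 4 in this assay. The estimate for compound 4 is 50000 nM, with a range from 25000 nM to 100000 nM. This corresponds to an expected step of a 1.0-fold lower number from compound 3 to compound 4 (0.01 log units; within the scatter) for compound 4.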

Compound 4, half-maximal inhibitory concentration: 40900 nM
The estimate for compound 4 lay 1.2-fold (0.09 log units) above the measured number; the measured number falls inside the stated range.
By their numbers in this assay, from the lowest: compounds 2, 4, 1 and 3 (each within the scatter of the next).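

In this assay, the change of ethyl in place of hydrogen on a saturated chain carbon, eight bonds along the chain from an aromatic nitrogen, can now be read on a second core, and a 1.3-fold lower number from compound 3 to compound 4 (0.10 log units; within the scatter) matches the step seen without the nitro group: the same change on two cores in this assay, a 1.0-fold lower number (0.02 log units; within the scatter) from compound 1 to compound 2 and a 1.3-fold lower number (0.10 log units; within the scatter) from compound 3 to compound 4, 1.2-fold (0.08 log units) apart, within the scatter of two such steps. The nitro change can now also be read on the longer chain, where a 1.0-fold higher number from compound 2 to compound 4 (0.02 log units; within the scatter) agrees with the step on the shorter chain: the same change on two cores in this assay, a 1.2-fold higher number (0.09 log units; within the scatter) from compound 1 to compound 3 and a 1.0-fold higher number (0.02 log units; within the scatter) from compound 2 to compound 4, 1.2-fold (0.08 log units) apart, within the scatter of two such steps. Across these four compounds, neither change moves the number beyond the scatter, and neither step differs beyond the scatter when the other change is present.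

On these data alone, it remains open whether a carboxylic acid or an amine at the end of the chain, or a much longer chain, would shift the number. The same question holds for a methoxy group in place of the nitro group on the phenyl.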